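Adding ethyl to the chain of a weak methoxy compound

The source may hold more compounds than are shown below. What is called first, only, known or untested is meant among the compounds shown, and "the series" means these compounds.

Measured in a functional assay on HCT-116 cells (Homo sapiens) for antiproliferative activity, read by MTT assay, with a stated time of 48 h; a higher number here means a weaker inhibitor, a lower number a stronger inhibitor:
Compound 1 `CCCCCCC(CCO)n1cnc2c(Cl)ncnc21`: 11900 nM
Compound 2 `CCCCCCC(CCO)n1cnc2c(OC)ncnc21`: > 50000 nM (a limit)
Compound 3 `CCCCCCC(CCO)n1cnc2c(NC)ncnc21`: > 50000 nM (a limit)

Compound 2 stands at > 50000 nM, which is a limit and not a number. From the compounds shown here alone, this is the limit of > 50000 nM in this assay, at which 2 of the 3 values shown sit, so its true position is unknown. Compound 1 is the only one of the three with a measured number.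

Compound 4 `CCCCCCCCC(CCO)n1cnc2c(OC)ncnc21` keeps the methoxy group of compound 2 and changes only the chain: ethyl in place of hydrogen on a saturated chain carbon, seven bonds along the chain from an aromatic nitrogen.

The measured steps all concern the group on the aromatic carbon. Putting methoxy in place of chloro gives an at least 4.2-fold higher number from compound 1 to compound 2 (0.62 log units; beyond the scatter), and putting methylamino in place of chloro gives an at least 4.2-fold higher number from compound 1 to compound 3 (0.62 log units; beyond the scatter). Swapping methylamino for methoxy gives a step that the two limits leave unreadable from compound 2 to compound 3. None of these steps alters the chain, so they offer no direct measure of this change and only show that compound 4 starts from a weak compound.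

In this assay, no firm direction can be expected, and the estimated step is an at least 1.1-fold lower number from compound 2 to compound 4 (0.04 log units; that floor lies within the scatter), with nothing expected beyond the scatter. The estimate for compound 4 is 45000 nM, with an expected range of 15000 nM to 130000 nM.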

Compound 4, half-maximal inhibitory concentration: 12800 nM
Beside the measured number, compound 4's estimate is 3.5-fold (0.55 log units) above it; measured number below the stated range.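

Until now every measured step concerned the group on the aromatic carbon, so nothing showed whether the chain mattered at all. In this assay ethyl in place of hydrogen on a saturated chain carbon, seven bonds along the chain from an aromatic nitrogen, gives an at least 3.9-fold lower number from compound 2 to compound 4 (0.59 log units; beyond the scatter) and so shows that this chain position can change the read-out even with the methoxy group kept, and that a methoxy compound need not stay at the assay's limit. Compound 2 sits at a limit and not a number, so the size of this step is only a floor: the limit of > 50000 nM in this assay, at which 2 of the 4 values shown sit.

The compounds shown leave open whether a longer chain, with propyl or butyl at this carbon in place of ethyl, would lower the number further or whether the effect stops at ethyl. They also leave open whether the same ethyl addition would act in the same way on compound 1 with its chloro group or on compound 3 with its methylamino group, or whether an amine or a carboxylic acid at the end of the chain would be tolerated.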